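The source may hold more compounds than are shown below. What is called first, only, known or untested is meant among the compounds shown, and "the series" means these compounds.

Compound 1 `COc1cc(/C=N/n2c(S)nnc2-c2cnccn2)cc(OC)c1OC`: 169000 nM
Compound 2 `Sc1nnc(-c2cnccn2)n1/N=C/c1ccc(Cl)cc1`: 218000 nM

In an ADME assay on NIH3T3 cells (Mus musculus) for cytotoxicity, read by MTT assay, with a stated time of 24 h (on this read-out higher numbers stand for weaker inhibition and lower numbers for stronger inhibition), compound 2 gives 218000 nM, which lies within the scatter of compound 1 at 169000 nM. Compound 3 `Oc1ccccc1/C=N/n1c(S)nnc1-c1cnccn1` follows from compound 2 with 2-hydroxyphenyl in place of 4-chlorophenyl on a carbon with a double bond to nitrogen. Going by the values given here, the series offers no measured step that differs in one place, so the only guide is these two close values. No change beyond the scatter is expected in this assay. The expected step is a 1.4-fold lower number from compound 2 to compound 3 (0.13 log units; within the scatter). For compound 3 the estimate is 160000 nM, with an expected range of 70000 nM to 350000 nM.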

Compound 3, half-maximal inhibitory concentration: 131000 nM
Compound 3: the middle estimate sits 1.2-fold (0.09 log units) above what was measured; the measured number falls inside the stated range.
By their numbers in this assay, from the lowest: compounds 3, 1 and 2 (each within the scatter of the next).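

In this assay the series now has a one-place step: on a carbon with a double bond to nitrogen, 2-hydroxyphenyl in place of 4-chlorophenyl gives a 1.7-fold lower number from compound 2 to compound 3 (0.22 log units; within the scatter) and this lies within the scatter. Exchanging these two groups, with the hydrogen-bond donor and acceptor counted for 2-hydroxyphenyl, therefore shifts the read-out by no more than the scatter. No measurement available here accounts for this result.

Still open, going by these compounds, is whether a phenyl carrying an amine or a carboxylic acid at this place would give a step beyond the scatter. On these data alone, a longer chain in place of the phenyl is equally open.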